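This account rests on a few compounds, and the source may have more. Where it says the series, first, only, none or still open, it means among the compounds named here.

In a physicochemical assay for lipophilicity, at pH 7.4 (on this read-out lower numbers stand for lower lipophilicity and higher numbers for higher lipophilicity), compound 2 (`CNC(=O)c1cc(C(=O)N[C@H]2[C@@H]3COC[C@@H]32)cc2c1O[C@H](CF)[C@H]2c1ccccc1`) reads 3.6 as the reference point for this step. That is level, within the scatter, with compound 1 (`CNC(=O)c1cc(C(=O)N[C@H]2[C@@H]3COC[C@@H]32)cc2c1OC[C@H]2c1ccccc1`) at 3.3 and clearly under compound 3 (`CNC(=O)c1cc(C(=O)N[C@H]2C[C@@H]2C)cc2c1OC[C@@]2(C)c1ccccc1`) at 4.7 in the same read-out.

The step leads to compound 4 (`CNC(=O)c1cc(C(=O)N[C@@H]2C[C@H]2C)cc2c1O[C@H](CF)[C@H]2c1ccccc1`) and the change is a group of 4 heavy atoms (4 carbon; one three-membered non-aromatic ring of carbon only) in place of a group of 6 heavy atoms (5 carbon, 1 oxygen; one three-membered non-aromatic ring of carbon only, one five-membered non-aromatic ring with 1 hetero atom), on an amide-type nitrogen with 2-methylcyclopropyl as the entering group. Among the measured compounds shown here, the only measured single-place step is a number 0.30 log units higher from compound 1 to compound 2 (within the scatter) and it concerns fluoromethyl in place of hydrogen, not this amide-type nitrogen, so it gives no direct size for the change. For the measured compounds named here, the one pointer is compound 3 at 4.7 which also carries 2-methylcyclopropyl on that nitrogen, although its core differs from that of compound 2 as well.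

Going by the values given here, a rise beyond the scatter is therefore expected, and the estimated step is a number 0.90 log units higher from compound 2 to compound 4 (beyond the scatter) with no clean measured pair behind it. For compound 4 the estimated value is 4.5 with an expected range from 4.1 to 4.9 on this reasoning.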

Compound 4, distribution coefficient: 4.5
Compound 4: the middle estimate sits on the measured number at the digits printed, and the stated range covers the measured number.
By their numbers in this assay, from the lowest: compounds 1 and 2 (each within the scatter of the next); then compounds 4 and 3 (each within the scatter of the next).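

With the rest of compound 2 unchanged, in this assay 2-methylcyclopropyl in place of the group of 6 heavy atoms on the amide-type nitrogen gives a number 0.90 log units higher from compound 2 to compound 4 (beyond the scatter) as the first single-place step read at this position. The only earlier such step, a number 0.30 log units higher from compound 1 to compound 2 (within the scatter) for fluoromethyl in place of hydrogen on a saturated ring carbon, lay at another place and stayed within the scatter, so the amide-type nitrogen is the one place shown here where a single change moves the read-out beyond the scatter. No measured evidence accounts for the size of this step.

Going by these compounds, whether the same exchange gives a step of similar size on the core of compound 1 remains open. Also open, on these data alone, is how an unsubstituted cyclopropyl, a longer alkyl chain or a carboxylic acid on that nitrogen would read.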